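Exchanging One Group on Compound 2

A few compounds are considered here, and "the series" means these few. Any claim that something is new, unique, unknown or untested is made for them only; others in the source may bear on it.

Measured in a functional assay on SK-OV-3 cells (Homo sapiens) for antiproliferative activity, read by MTT assay, with a stated time of 72 h; a higher number here means a weaker inhibitor, a lower number a stronger inhibitor:
Compound 1 `O=C(CCc1cccc2c1B(O)OC2)Nc1ccccc1`: 200 nM
Compound 2 `O=C(CCc1cccc2c1B(O)OC2)Nc1cccc(-c2ccc(OC(F)(F)F)cc2)c1`: 560 nM

Of these two compounds, compound 2 has the higher number and is therefore the weaker inhibitor, and its gap to compound 1 lies beyond the usual scatter. The next compound, compound 3 `N#Cc1ccc(-c2cccc(NC(=O)CCc3cccc4c3B(O)OC4)c2)cc1`, has not yet been measured. It differs from compound 2 at a single place, with cyano in place of trifluoromethoxy on an aromatic carbon, para to a large group (cyano in place of trifluoromethoxy on an aromatic carbon).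

Going by the values given here, no measured pair shows this exchange, so the data offer no direct guide to its effect. Among the compounds with values here, the only anchors are two values: compound 1, which lacks both groups, gives 200 nM, and compound 2 gives 560 nM. A value for compound 3 near this span seems the reasonable expectation. In this assay, the expected change is a small move toward a lower number, probably not beyond the scatter, a 1.5-fold lower number from compound 2 to compound 3 (0.17 log units; within the scatter). For compound 3 the estimated value is 380 nM, with an expected range of 130 nM to 1000 nM.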

Compound 3, half-maximal inhibitory concentration: 340 nM
Estimate against measurement, compound 3: 1.1-fold (0.05 log units) above; the range from low to high includes it.
By their numbers in this assay, from the lowest: compounds 1, 3 and 2 (each within the scatter of the next, the first and the last beyond it).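

In this assay, putting cyano in place of trifluoromethoxy on this aromatic carbon, para to a large group, gives a 1.6-fold lower number from compound 2 to compound 3 (0.22 log units; within the scatter). Going by these compounds alone, this is the first direct reading of the exchange, and it shows that the two groups cannot be told apart here, even though the one that enters has fewer heavy atoms than the one that leaves. The whole 4-cyanophenyl group in place of hydrogen gives a 1.7-fold higher number from compound 1 to compound 3 (0.23 log units; within the scatter), so compound 3 also cannot be told apart from the unsubstituted compound 1, and nothing measured alongside these numbers offers an explanation for either small step.

Within the data shown here, only two groups have been read at this position, so it remains open whether an amine, a carboxylic acid or a longer chain on the same carbon would move the number beyond the scatter. From the compounds shown here alone, it also remains open whether cyano and trifluoromethoxy would stay this close on a different core or in a different cell line.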